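The source may hold more compounds than are shown below. What is called first, only, known or untested is meant among the compounds shown, and "the series" means these compounds.

In a functional assay for antagonist activity at transient receptor potential cation channel subfamily V member 1 (Rattus norvegicus) (on this read-out higher numbers stand for weaker inhibition and lower numbers for stronger inhibition), compound 1 `CC(C)(C)c1ccc(NC(=O)c2ccc(-c3ncccc3NS(C)(=O)=O)cc2)cc1` gives 35 nM, compound 2 `CCS(=O)(=O)Nc1cccnc1-c1ccc(C(=O)Nc2ccc(C(C)(C)C)cc2)cc1` gives 4 nM and compound 3 `CC(C)(C)c1ccc(NC(=O)c2ccc(-c3ncccc3N(S(C)(=O)=O)S(C)(=O)=O)cc2)cc1` gives 0.4 nM, the lowest of the three numbers; the steps to it are an 88-fold lower number from compound 1 to compound 3 (1.94 log units; beyond the scatter) and a 10-fold lower number from compound 2 to compound 3 (1.00 log units; beyond the scatter). Compound 4 `CC(C)(C)c1ccc(NC(=O)c2ccc(-c3ncccc3-c3ncc[nH]3)cc2)cc1` carries 1H-imidazol-2-yl in place of bis(methylsulfonyl)amino on an aromatic carbon. The measured steps all leave the sulfonamide nitrogen in place and only vary what sits on it, the smallest being an 8.8-fold lower number from compound 1 to compound 2 (0.94 log units; beyond the scatter); none removes that group, so they bear on this change only loosely, and the direction is read from the fall seen when the nitrogen gains a second sulfonyl. In this assay compound 4 is expected to come in at about 50 nM, within a range of 5 nM to 500 nM. The step this estimate implies is a 130-fold higher number from compound 3 to compound 4 (2.10 log units; beyond the scatter), a loss expected beyond the scatter.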

Compound 4, half-maximal inhibitory concentration: 694 nM
Compound 4: the middle estimate sits 14-fold (1.14 log units) below what was measured; measured number outside the range, above it.
By their numbers in this assay, from the lowest: compound 3; then compound 2; then compound 1; then compound 4.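

1H-imidazol-2-yl on this aromatic carbon gives the highest number of the four, with a 1700-fold higher number from compound 3 to compound 4 (3.24 log units; beyond the scatter), a 170-fold higher number from compound 2 to compound 4 (2.24 log units; beyond the scatter) and a 20-fold higher number from compound 1 to compound 4 (1.30 log units; beyond the scatter). The earlier compounds shown here varied only the sulfonyl substitution on the nitrogen; this swap shows that the five-membered aromatic ring does not stand in for any of the three sulfonamide groups. No evidence shown accounts for the loss.

As far as these compounds go, whether any sulfonyl group is required at this carbon remains open. A plain amine, an acetamide or an N-methylimidazole at this position would help to separate these possibilities.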